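Triazolyl sulfonamides and ureas: fluorine position on urea aryl

This account rests on a few compounds, and the source may have more. Where it says the series, first, only, none or still open, it means among the compounds named here.

Three compounds have numbers in an assay for inhibition of ATP-dependent RNA helicase DDX3X (Homo sapiens), read by FRET, with a stated time of 40 min, in the presence of a further agent that is not named here; on this read-out higher numbers stand for weaker inhibition and lower numbers for stronger inhibition. Compound 1 `CCOCc1cn(-c2cccc(S(=O)(=O)Nc3ccccc3C(F)(F)F)c2)nn1` gives 400 nM in this assay. Compound 2 `CCCCc1cn(-c2cccc(S(=O)(=O)Nc3ccccc3OC)c2)nn1` gives 180 nM in this assay. Compound 3 `CC(C)CCc1cn(-c2ccc(NC(=O)Nc3ccccc3F)cc2)nn1` gives 120 nM in this assay. Compound 3 and compound 2 lie within the usual scatter of each other, so no order between them is claimed; compound 1 stands beyond the scatter, at a higher number than compound 3. Within the data shown here, no pair among the three differs in one place only, so no single step is counted among the measured compounds.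

Compound 4 `CC(C)CCc1cn(-c2ccc(NC(=O)Nc3cccc(F)c3)cc2)nn1` is not yet measured. It differs from compound 3 by 3-fluorophenyl in place of 2-fluorophenyl on an amide-type nitrogen, the two sharing the same atoms joined differently. Among the measured compounds shown here, with no comparable step in hand, the expectation rests on compound 3 alone, whose value is 120 nM. For compound 4 a step of no more than the scatter is expected, in either direction, so a 1.3-fold higher number from compound 3 to compound 4 (0.10 log units; within the scatter) is the estimated move. Compound 4 is therefore expected at 150 nM in this assay, with a range from 50 nM to 450 nM.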

Compound 4, half-maximal inhibitory concentration: 200 nM
Estimate against measurement, compound 4: 1.3-fold (0.12 log units) below; the range from low to high includes it.
By their numbers in this assay, from the lowest: compounds 3, 2, 4 and 1 (each within the scatter of the next, the first and the last beyond it).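

Notes on the aryl group on the amide-type nitrogen: in this assay the exchange of 2-fluorophenyl for 3-fluorophenyl supplies the first single-place step in the series, a 1.7-fold higher number from compound 3 to compound 4 (0.22 log units; within the scatter). At this place the two fluorophenyl isomers are therefore not told apart on this read-out, and moving the fluorine between these two positions leaves no readable difference. Nothing in hand bears on this result.

Still open, going by these compounds, is whether this place responds at all to a change of substituent rather than of its position, which unsubstituted phenyl or a chlorophenyl group on the same nitrogen would address. The sulfonamides, compound 1 and compound 2, differ from the fluorophenyl compounds in more than one place, and so the data give no single-step link between the two subseries.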